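The source may hold more compounds than are shown below. What is called first, only, known or untested is meant among the compounds shown, and "the series" means these compounds.

Measured so far in an ADME assay on HaCaT cells (Homo sapiens) for cytotoxicity, read by MTT assay, with a stated time of 48 h; on this read-out higher numbers stand for weaker inhibition and lower numbers for stronger inhibition:
- Compound 1 `Fc1ccc2[nH]c(-c3cn(-c4ccccc4)nc3-c3ccccc3)nc2c1`: > 50000 nM
- Compound 2 `Fc1ccc(-c2nn(-c3ccccc3)cc2-c2nc3cc(C(F)(F)F)ccc3[nH]2)cc1`: > 50000 nM
- Compound 3 `Fc1ccc2[nH]c(-c3cn(-c4ccccc4)nc3-c3ccc(Cl)cc3)nc2c1`: > 50000 nM

All three entries are limits of the assay, not numbers. Compound 3 stands at > 50000 nM, which is only a limit. For the measured compounds named here, the series so far shows (the limit of > 50000 nM in this assay, at which 3 of the 3 values shown sit).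

Compound 4 `FC(F)(F)c1ccc2[nH]c(-c3cn(-c4ccccc4)nc3-c3ccc(Cl)cc3)nc2c1` has trifluoromethyl in place of fluoro on an aromatic carbon. Going by the values given here, the one measured step, a step that the two limits leave unreadable from compound 1 to compound 3, gives no size to build on. Compound 2 also carries trifluoromethyl. Compound 2 reads > 50000 nM, again a limit. Nothing measured therefore points to a real shift in this assay, so the expected step is none beyond the scatter: a number no higher from compound 3 to compound 4 (the limit leaves the size open). For compound 4 the estimate is 50000 nM, with an expected range of 25000 nM to 100000 nM.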

Compound 4, half-maximal inhibitory concentration: 41800 nM
Compound 4: the middle estimate sits 1.2-fold (0.08 log units) above what was measured, and the stated range covers the measured number.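

For the compounds shown here, compound 4 is the first compound here to give a true number rather than a limit in this assay: the limit of > 50000 nM in this assay, at which 3 of the 4 values shown sit. Trifluoromethyl in place of fluoro at this position gives an at least 1.1-fold lower number from compound 3 to compound 4 (0.07 log units; that floor lies within the scatter), and chloro in place of fluoro on the other aromatic ring gives an at least 1.1-fold lower number from compound 2 to compound 4 (0.07 log units; that floor lies within the scatter). Neither change is therefore shown to move the read-out beyond the scatter.

As far as these compounds go, the true size of both steps stays open. Also open, from the compounds shown here alone, is how an amine or a carboxylic acid on this aromatic carbon would read in this assay.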